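The source may report more compounds than this note shows. Statements on the series, on what has been measured and on what is new or still open speak of the compounds shown alone.

Compound 1 `COc1ccc(C2=C(c3cc(OC)c(OC)c(OC)c3)C(=O)CC2O[SiH2]C(C)(C)C)cc1`: > 100 ug/mL
Compound 2 `COC(=O)c1cc(C2=C(c3cc(OC)c(OC)c(OC)c3)C(=O)CC2O[SiH2]C(C)(C)C)ccc1OC`: > 100 ug/mL
Compound 3 `COc1ccc(C2=C(c3cc(OC)c(OC)c(OC)c3)C(=O)CC2OC(C)=O)cc1NC=O`: 2 ug/mL

All three were tested in an ADME assay on MIA PaCa-2 cells (Homo sapiens) for cytotoxicity, read by MTT assay, with a stated time of 72 h; a lower number here means a stronger inhibitor, a higher number a weaker inhibitor. Compound 2 gives > 100 ug/mL, which is a limit and not a number. Compound 1 also gives a limit, > 100 ug/mL. Together they stand at the limit of > 100 ug/mL in this assay, at which 2 of the 3 values shown sit. Compound 3 gives a number, 2 ug/mL.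

Compound 4 `COc1cc(C2=C(c3ccccc3)C(O[SiH2]C(C)(C)C)CC2=O)cc(OC)c1OC` is related to compound 2 by phenyl in place of 4-methoxy-3-(methoxycarbonyl)phenyl on a double-bonded ring carbon. Within the data shown here, the one measured step at this group is a step that the two limits leave unreadable from compound 1 to compound 2, so it offers no size to carry over. Compound 2, at > 100 ug/mL, gives only a limit as a starting point, so no direction can be argued. The expected a number no higher from compound 2 to compound 4 (the limit leaves the size open) is none beyond the scatter. For compound 4 the estimate is 100 ug/mL, with an expected range from 40 ug/mL to 250 ug/mL.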

Compound 4, half-maximal inhibitory concentration: > 100 ug/mL
Compound 4: a limit, no number; the forecaster's own chance of this, stated with the estimate: 70%; the middle value lies on the limit itself.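

Compound 4 gives > 100 ug/mL in this assay, which is a limit and not a number. Its steps from compound 1 and compound 2 therefore cannot be read: the limit of > 100 ug/mL in this assay, at which 3 of the 4 values shown sit.

The compounds shown leave open how large any of these single changes is.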